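This account rests on a few compounds, and the source may have more. Where it says the series, first, only, none or still open, it means among the compounds named here.

Compound 1, `CNC(=O)c1cc(OC)n(-c2ccccc2)n1`, stands highest of the two compounds examined so far in a functional assay on the whole organism (strain Wistar) for inhibition, with Rattus norvegicus as the target, read by paw edema, with stated times of 30 min and 3 h, at a dose of 100 mg/kg by the oral route; a higher number here means more inhibition at the dose given (going by the name of the read-out), a lower number less inhibition; compound 1 reaches 57.9%. Within the data shown here, compound 2, `COc1cc(C(=O)NC(C)C)nn1-c1ccccc1`, is the only other measured compound, and in this assay compound 2 gives 24.8%. Among the measured compounds shown here, the one measured step, a number 33.1 percentage points lower from compound 1 to compound 2 (beyond the scatter), concerns isopropyl in place of methyl on an amide-type nitrogen, a different part of the molecule. Compound 3, `CCCCOc1cc(C(=O)NC)nn1-c1ccccc1`, is not yet measured; compared with compound 1 it carries propyl in place of hydrogen on a saturated chain carbon bound to an oxygen on an aromatic ring. For the measured compounds named here, no measured step touches the chain on the ring oxygen, so nothing bears directly on this change. Going by the values given here, the sole step available shows that adding carbon elsewhere cost compound 2 much of its effect, which is the only hint at hand. A moderate drop beyond the scatter is therefore expected, a number 17.9 percentage points lower from compound 1 to compound 3 (beyond the scatter), with wide uncertainty. For compound 3 in this assay the estimate is 40%, in a range from 15% to 65%.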

Compound 3, a percentage reported as inhibition, in the whole organism at one dose (the size of the read-out at that dose, not a potency): 65%
For compound 3 the middle estimate is 25 percentage points below the measured one; low and high end bracket the measured number.
By their numbers in this assay, from the lowest: compound 2; then compounds 1 and 3 (each within the scatter of the next).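

Replacing methoxy with butoxy leaves compound 1 and compound 3 indistinguishable in this assay (a number 7.1 percentage points higher from compound 1 to compound 3 (within the scatter)). This position, the saturated chain carbon bound to an oxygen on an aromatic ring, therefore accepts propyl in place of hydrogen at this dose, whereas the isopropyl step on the amide-type nitrogen gave a large loss (a number 33.1 percentage points lower from compound 1 to compound 2 (beyond the scatter)), so added carbon does not carry the same cost at both places in these compounds. No evidence is available on what lies behind this contrast.

Going by these compounds, it remains open whether a chain longer than butyl, or a butyl chain ending in an amine or a carboxylic acid, would keep the effect at this position. Also open, on these data alone, is how a compound combining butoxy with isopropyl on the amide-type nitrogen would behave.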